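The source may report more compounds than this note shows. Statements on the series, on what has been measured and on what is new or still open speak of the compounds shown alone.

Measured in a functional assay on U2OS cells (Homo sapiens) for antiproliferative activity, read by MTT assay, with a stated time of 72 h; a higher number here means a weaker inhibitor, a lower number a stronger inhibitor:
- Compound 1 `Cc1cc(C)cc(C(=O)Nc2nc3ccc(NC(=O)CSc4ccc(Cl)cc4)cc3s2)c1`: > 100000 nM, a limit of the assay
- Compound 2 `Cc1ccc(C(=O)Nc2nc3ccc(NC(=O)CSc4ccc(Cl)cc4)cc3s2)cc1`: 3190 nM
- Compound 3 `O=C(CSc1ccc(Cl)cc1)Nc1ccc2nc(NC(=O)c3ccc4ccccc4c3)sc2c1`: 14500 nM

Of the two true numbers, the higher belongs to compound 3, at 14500 nM. Compound 4 `O=C(CSc1ccc(Cl)cc1)Nc1ccc2nc(NC(=O)c3ccc(C(F)(F)F)cc3)sc2c1` differs from it in one place: 4-(trifluoromethyl)phenyl in place of naphthalen-2-yl on a carbonyl carbon. Changes on this carbonyl carbon have already moved the numbers: an at least 31-fold lower number from compound 1 to compound 2 (1.49 log units; beyond the scatter), an at least 6.8-fold lower number from compound 1 to compound 3 (0.83 log units; beyond the scatter) and a 4.5-fold higher number from compound 2 to compound 3 (0.66 log units; beyond the scatter). The last step is the closest guide, since 4-methylphenyl, like the entering 4-(trifluoromethyl)phenyl, is a substituted phenyl group. Going by the values given here, compound 4 is therefore expected to move modestly back toward compound 2 in this assay, on the evidence of only three compounds. The expected change is a 2.9-fold lower number from compound 3 to compound 4 (0.46 log units; beyond the scatter). Compound 4 is estimated at 5000 nM, with a range of 1500 nM to 20000 nM.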

Compound 4, half-maximal inhibitory concentration: 2890 nM
Compound 4: the middle estimate sits 1.7-fold (0.24 log units) above what was measured; measured number inside the range.
By their numbers in this assay, from the lowest: compounds 4 and 2 (each within the scatter of the next); then compound 3. At a limit, above all of these: compound 1.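

In this assay, the single-ring 4-(trifluoromethyl)phenyl in place of the two-ring naphthalen-2-yl gives a 5.0-fold lower number from compound 3 to compound 4 (0.70 log units; beyond the scatter), while trifluoromethyl in place of methyl on an aromatic carbon gives a 1.1-fold lower number from compound 2 to compound 4 (0.04 log units; within the scatter), so these two substituted phenyl groups cannot be told apart here. Against the 3,5-dimethylphenyl group, the step is an at least 34-fold lower number from compound 1 to compound 4 (1.53 log units; beyond the scatter). Compound 1 stands at a limit, so that step is only a bound: the limit of > 100000 nM in this assay, at which 1 of the 4 values shown sits.

Still open, going by these compounds, is how 3-methylphenyl would stand on this carbonyl carbon. Also open, on these data alone, is whether a 4-aminophenyl group, a 4-carboxyphenyl group or a cyclohexyl ring would keep the number of compound 4.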